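The source may report more compounds than this note shows. Statements on the series, on what has been measured and on what is new or still open speak of the compounds shown alone.

Measured so far in a functional assay on SW-620 cells (Homo sapiens) for inhibition; on this read-out lower numbers stand for stronger inhibition and higher numbers for weaker inhibition:
- compound 1, `CCCN1C(=O)NC2(CSC3=C2C(=O)c2ccccc2C3=O)C1=O`: 379 nM
- compound 2, `CCCCN1C(=O)NC2(CSC3=C2C(=O)c2ccccc2C3=O)C1=O`: 740 nM
- compound 3, `NCCCN1C(=O)NC2(CSC3=C2C(=O)c2ccccc2C3=O)C1=O`: 52 nM

Compound 2 gives the highest number of the three; its nearest neighbour is compound 1, which lies at a 2.0-fold higher number from compound 1 to compound 2 (0.29 log units; within the scatter), so the two stand together within the scatter, while compound 3 sits far below it.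

Compound 4, `CN(C)CCN1C(=O)NC2(CSC3=C2C(=O)c2ccccc2C3=O)C1=O`, has not been measured. It differs from compound 2 as follows: dimethylamino in place of ethyl on a saturated chain carbon, two bonds along the chain from an amide-type nitrogen in a ring.

Within the data shown here, two measured steps bear on this change. Replacing the terminal part of the chain on compound 2 with an amino group gave a 14-fold lower number from compound 2 to compound 3 (1.15 log units; beyond the scatter), and the parallel change from compound 1 gave a 7.3-fold lower number from compound 1 to compound 3 (0.86 log units; beyond the scatter). In both cases introducing a nitrogen on the chain lowered the number clearly beyond the scatter. Compound 4 likewise carries a nitrogen on the chain, here as dimethylamino, and two bonds along from the ring nitrogen rather than three. Among the measured compounds shown here, whether the shorter spacing and the two added methyl groups matter cannot be read from the three measured compounds, so the expected step for compound 4 is set smaller than the one seen for compound 3: a 5.7-fold lower number from compound 2 to compound 4 (0.76 log units; beyond the scatter) is expected. Compound 4 is therefore estimated at 130 nM in this assay, with a range of 40 nM to 420 nM.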

Compound 4, half-maximal inhibitory concentration: 57 nM
For compound 4 the middle estimate is 2.3-fold (0.36 log units) above the measured one; the range from low to high includes it.
By their numbers in this assay, from the lowest: compounds 3 and 4 (each within the scatter of the next); then compounds 1 and 2 (each within the scatter of the next).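

In this assay, the gain from a chain nitrogen survives when it is carried as dimethylamino, two bonds along the chain from an amide-type nitrogen in a ring: there is a 13-fold lower number from compound 2 to compound 4 (1.11 log units; beyond the scatter) and a 6.6-fold lower number from compound 1 to compound 4 (0.82 log units; beyond the scatter). Set against the amino chain, the change leaves the number within the scatter, with a 1.1-fold higher number from compound 3 to compound 4 (0.04 log units; within the scatter), so in this pair the shorter spacing and the two methyl groups on the nitrogen together leave no mark on the read-out. No measurement at hand explains these steps.

On these data alone, the spacing and the methyl groups change together here, so their separate contributions remain open; an amino group on the shorter chain, or dimethylamino on the longer one, would separate them. As far as these compounds go, whether the chain end must be an amine at all is also open, as a hydroxyl or a carboxylic acid there would show.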